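Tert-Butyl in Place of Amino: An Unreadable Cytotoxicity Step

The source may hold more compounds than are shown below. What is called first, only, known or untested is meant among the compounds shown, and "the series" means these compounds.

Compound 1 `Cc1cc(NC(=O)Nc2ccc(N)cc2)c2ccccc2n1` is the starting point. In an ADME assay on HepG2 cells (Homo sapiens) for cytotoxicity, with a stated time of 72 h (on this read-out lower numbers stand for an effect already at smaller amounts and higher numbers for an effect only at larger amounts of compound), compound 1 reaches only a limit of the assay, > 25000 nM, and not a number. Compound 2 `Cc1cc(NC(=O)Nc2ccccc2F)c2ccccc2n1` likewise ends at a limit in this assay, > 25000 nM. Compound 3 `Cc1cc(NC(=O)Nc2cccnc2)c2ccccc2n1` also stops at a limit in this assay, > 25000 nM. Because all three values sit at the limit of > 25000 nM in this assay, at which 3 of the 3 values shown sit, the steps between them cannot be sized: a step that the two limits leave unreadable from compound 1 to compound 2, a step that the two limits leave unreadable from compound 1 to compound 3 and a step that the two limits leave unreadable from compound 2 to compound 3.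

Compound 4 `Cc1cc(NC(=O)Nc2ccc(C(C)(C)C)cc2)c2ccccc2n1` differs from compound 1 in one place: tert-butyl in place of amino on an aromatic carbon. Going by the values given here, none of the measured steps touches this group, and none has a readable size, so they give neither a direction nor a size for this assay. The expectation is therefore that compound 4 lands at the same limit again, with no step beyond the scatter. For compound 4 the estimate in this assay is 30000 nM, ranging from 10000 nM to 100000 nM. That estimate means an expected step that the limit leaves unreadable from compound 1 to compound 4.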

Compound 4, half-maximal effective concentration: 17000 nM
Beside the measured number, compound 4's estimate is 1.8-fold (0.25 log units) above it; low and high end bracket the measured number.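

Swapping amino for tert-butyl on this aromatic carbon gives the first change in this series that can be given any size at all: an at least 1.4-fold lower number from compound 1 to compound 4 (0.16 log units; that floor lies within the scatter). That figure is only a floor, set by the limit of compound 1, so the step may be larger, but nothing shown proves that it goes beyond the scatter. Among the compounds shown, compound 4 alone gives a number in this assay, while the others stop at a single limit: the limit of > 25000 nM in this assay, at which 3 of the 4 values shown sit.

As far as these compounds go, whether any carbon group on this ring carbon would give a number, or whether this needs tert-butyl itself, stays open, and a methyl, an isopropyl or a cyclohexyl group there would help to separate the two. From the compounds shown here alone, how a carboxylic acid or a methoxy group at the same place would read in this assay also remains unknown.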